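Adding Chloro to the Second Phenyl of Compound 1

This account rests on a few compounds, and the source may have more. Where it says the series, first, only, none or still open, it means among the compounds named here.

Compound 1 `O=C(NOCc1ccccc1F)c1cn(-c2ccccc2)nc1-c1ccccc1` and compound 2 `O=C(NOCc1ccc(Cl)cc1Cl)c1cn(-c2ccccc2)nc1-c1ccccc1` share one core and differ only in the group on the saturated chain carbon bound to an oxygen. In a functional assay on A549 cells (Homo sapiens) for antiproliferative activity, read by MTT assay, with a stated time of 48 h, in the presence of a further agent that is not named here (a lower number here means a stronger inhibitor of growth, a higher number a weaker inhibitor of growth), compound 1 gives 5940 nM, the lowest of the two numbers shown; compound 2 gives 7350 nM, and the step of a 1.2-fold higher number from compound 1 to compound 2 (0.09 log units; within the scatter) lies within the scatter. Compound 3 `O=C(NOCc1ccccc1F)c1cn(-c2ccccc2)nc1-c1ccc(Cl)cc1` differs from compound 1 by chloro in place of hydrogen on an aromatic carbon, a change that reads phenyl to 4-chlorophenyl when cut one bond further out. Going by the values given here, no measured step touches this ring: the only step available, a 1.2-fold higher number from compound 1 to compound 2 (0.09 log units; within the scatter), concerns the group on the saturated chain carbon at the other end of the molecule and stayed within the scatter. The data therefore hold nothing on how a chloro group at this position alters growth inhibition. With nothing to point either way, the expected step of a 1.0-fold lower number from compound 1 to compound 3 (0.00 log units; within the scatter) is estimated to stay within the scatter. Compound 3 is accordingly estimated at 5900 nM in this assay, with a range from 2500 nM to 14000 nM that allows for the untested position.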

Compound 3, concentration for 50% growth inhibition: 12100 nM
Compound 3: middle estimate off by 2.1-fold (0.31 log units), on the low side, within the range that was stated.
By their numbers in this assay, from the lowest: compounds 1, 2 and 3 (each within the scatter of the next, the first and the last beyond it).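

In this assay, going by these compounds alone, the first change to move the number beyond the usual scatter is this one, placing chloro on an aromatic carbon para to a large group: a 2.0-fold higher number from compound 1 to compound 3 (0.31 log units; beyond the scatter). The step is modest, but it shows that growth inhibition responds to a change on this ring, and that phenyl is preferred to 4-chlorophenyl here, whereas the earlier comparison, made at the other end of the molecule, showed only a change within the scatter. Nothing among the data given explains why chloro in place of hydrogen at this position gives a weaker inhibitor of growth.

The compounds shown leave open whether the step belongs to chloro itself or would also appear with another group at this position, such as fluoro, methoxy, an amine or a carboxylic acid. They also leave open whether 4-chlorophenyl would give a similar step when paired with the 2,4-dichlorophenyl group of compound 2 rather than the 2-fluorophenyl group of compound 1, and whether chloro elsewhere on the same ring would behave in the same way.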